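A few compounds are considered here, and "the series" means these few. Any claim that something is new, unique, unknown or untested is made for them only; others in the source may bear on it.

Compound 3 `COc1ccc(Sc2nc3cc(N)cc(N)c3nc2-c2ccccc2)cc1` belongs to a small set of three measured compounds sharing one core. Compound 1 `COc1ccc(CNc2nc3cc(N)cc(N)c3nc2-c2ccccc2)cc1OC` gives 45700 nM in a functional assay on UO-31 cells (Homo sapiens) for inhibition, read by sulforhodamine B assay, with a stated time of 48 h; on this read-out lower numbers stand for stronger inhibition of growth and higher numbers for weaker inhibition of growth. Compound 2 `COc1ccc(CNc2nc3cc(N)cc(N)c3nc2-c2ccccc2)cc1` gives 28800 nM in the same assay. Among the compounds with values here, the only measured step, a 1.6-fold lower number from compound 1 to compound 2 (0.20 log units; within the scatter), concerns a substituent on the pendant benzyl group and lies within the scatter. Compound 3 stands apart from these two: in this assay it is reported only as a limit, < 100000 nM, so its position on the numbers is not fixed, and the limit of < 100000 nM in this assay, at which 1 of the 3 values shown sits, is the only thing known of it.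

Compound 4 `Nc1cc(N)c2nc(-c3ccccc3)c(Oc3ccc(F)cc3)nc2c1` is the compound to be measured. It differs from compound 3 by 4-fluorophenoxy in place of (4-methoxyphenyl)sulfanyl on an aromatic carbon. Within the data shown here, no measured step touches the linking atom or the substituent on the pendant aryl ring in this position, so the single measured step, small as it is, does not bear on this change. What the set shows is that compounds 1 and 2 sit close to each other while compound 3 carries a limit. On that basis the step that the limit leaves unreadable from compound 3 to compound 4 is expected to be of uncertain direction, and compound 4 is estimated at 40000 nM, within a range from 10000 nM to 100000 nM.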

Compound 4, concentration for total growth inhibition: 45700 nM
The estimate for compound 4 lay 1.1-fold (0.06 log units) below the measured number, and the stated range covers the measured number.
By their numbers in this assay, from the lowest: compounds 2, 1 and 4 (each within the scatter of the next).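

The step from compound 3 to compound 4 cannot be read, because compound 3 is reported only as a limit: the limit of < 100000 nM in this assay, at which 1 of the 4 values shown sits.

The compounds shown leave open whether 4-fluorophenoxy in place of (4-methoxyphenyl)sulfanyl changes the number at all, in which direction, and what the linking atom and the substituent on the pendant aryl ring each contribute.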